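Aryl ether swap on a shared unsaturated core

The source may report more compounds than this note shows. Statements on the series, on what has been measured and on what is new or still open speak of the compounds shown alone.

Of the compounds shown here, two have been measured. Compound 1 `COc1cccc(OC/C=C(\C)CC/C=C(\C)C2CC(=O)C(C)(C)O2)c1` carries a 3-methoxyphenyl ether; in a functional assay on FM3A cells (Mus musculus) for inhibition (a lower number here means a stronger inhibitor, a higher number a weaker inhibitor), compound 1 gives 68.7 ug/mL. Compound 2 `C/C(=C\COc1c(Cl)cccc1Cl)CC/C=C(\C)C1=CC(=O)C(C)(C)O1` carries a 2,6-dichlorophenyl ether on a core that differs from that of compound 1; in this assay compound 2 gives 35.3 ug/mL. That is the lower of the two numbers, but the gap to compound 1 lies within the usual scatter, so the two cannot be ranked against each other.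

Compound 3 `COc1cccc(OC/C=C(\C)CC/C=C(\C)C2=CC(=O)C(C)(C)O2)c1` is the next member, not yet measured in this assay. Relative to compound 2 the change is 3-methoxyphenyl in place of 2,6-dichlorophenyl on an oxygen on a saturated carbon; the core of compound 2 is kept. Among the compounds with values here, no measured pair isolates this change, so no direct step is known. Compound 1 holds the same 3-methoxyphenyl group on a different core and gives 68.7 ug/mL, close to compound 2, which suggests the aryl swap moves the number little. The step expected here is a 1.4-fold higher number from compound 2 to compound 3 (0.15 log units; within the scatter), none beyond the scatter. The estimate for compound 3 in this assay is 50 ug/mL, with a range from 25 ug/mL to 110 ug/mL.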

Compound 3, half-maximal inhibitory concentration: 45.9 ug/mL
Compound 3: the middle estimate sits 1.1-fold (0.04 log units) above what was measured, within the range that was stated.
By their numbers in this assay, from the lowest: compounds 2, 3 and 1 (each within the scatter of the next).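

On the oxygen on a saturated carbon, 3-methoxyphenyl in place of 2,6-dichlorophenyl is now a directly measured change on the core of compound 2. In this assay this change gives a 1.3-fold higher number from compound 2 to compound 3 (0.11 log units; within the scatter), and the core change with the 3-methoxyphenyl group held fixed gives a 1.5-fold lower number from compound 1 to compound 3 (0.18 log units; within the scatter); both steps lie within the scatter, so neither single change separates the compounds it connects. No data on the properties of these groups or cores bear on the results.

The compounds shown leave open whether the core change would read the same with 2,6-dichlorophenyl in place of 3-methoxyphenyl, since that fourth combination of aryl group and core is not among them. They also leave open whether any group at this place can move the number in this assay beyond the scatter, which an aryl ring carrying an amine or a carboxylic acid, or a longer chain in place of the aryl ring, could test.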